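The source may report more compounds than this note shows. Statements on the series, on what has been measured and on what is new or still open speak of the compounds shown alone.

Measured so far in a functional assay on A2780 cells (Homo sapiens) for antiproliferative activity, read by CellTiter-Glo, with a stated time of 4 days; on this read-out lower numbers stand for stronger inhibition and higher numbers for weaker inhibition:
- compound 1 `CC(=O)NCc1ncc2cc(COc3ccc(C(=O)NCc4cccnc4)cc3)n(CCC3CCCCC3)c2n1`: 15 nM
- compound 2 `O=C(/C=C/c1cccnc1)Nc1ccc(CN2C(=O)c3ccccc3C2=O)cc1`: "not determined" (no result reported)
- compound 3 `C[C@H](NC(=O)[C@@H]1CCCN1C)c1ccc(NC(=O)[C@H]2C[C@@H]2c2cccnc2)cc1`: 1 nM

Compound 3, at 1 nM, has the lower of the two numbers available, and its gap to compound 1, at 15 nM, lies beyond the scatter. Compound 2 gave no number and so offers no comparison. The unmeasured compound 4 `C[C@H](NC(=O)c1ncccn1)c1ccc(NC(=O)[C@H]2C[C@@H]2c2cccnc2)cc1` differs from compound 3 in one place: pyrimidin-2-yl in place of 1-methylpyrrolidin-2-yl on a carbonyl carbon. Here pyrimidin-2-yl takes the place of 1-methylpyrrolidin-2-yl on a carbonyl carbon, so a non-aromatic ring gives way to an aromatic one.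

Going by the values given here, no pair of measured compounds differs in one place, so the data hold no direct precedent for this exchange, and any forecast is uncertain. A modest loss of potency in this assay seems the likeliest outcome, though a result within the scatter of compound 3 would not be surprising. The expected change is a 3.0-fold higher number from compound 3 to compound 4 (0.48 log units; beyond the scatter). The estimated value for compound 4 is 3 nM, with an expected range from 0.8 nM to 12 nM.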

Compound 4, half-maximal inhibitory concentration: 14 nM
For compound 4 the middle estimate is 4.7-fold (0.67 log units) below the measured one, outside the stated range (above it).
By their numbers in this assay, from the lowest: compound 3; then compounds 4 and 1 (each within the scatter of the next).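

In this assay, going by these compounds alone, replacing 1-methylpyrrolidin-2-yl with pyrimidin-2-yl on a carbonyl carbon gives a 14-fold higher number from compound 3 to compound 4 (1.15 log units; beyond the scatter), the first step in these data that changes a single place. The result shows that the read-out is sensitive to the group at this position, even though the two groups have the same number of heavy atoms and neither carries a net charge. No available measurement accounts for the step.

The exchange alters ring size, aromaticity, hetero atom count and the defined stereocentre together, so the compounds shown leave open which of these differences goes with the weaker inhibition. Also open, as far as these compounds go, is whether pyrrolidin-2-yl without its methyl, 1-methylpiperidin-2-yl, pyridin-2-yl or phenyl on the same carbonyl carbon would give a number closer to that of compound 3 or compound 4.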